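This account rests on a few compounds, and the source may have more. Where it says the series, first, only, none or still open, it means among the compounds named here.

Three compounds have been measured so far in a functional assay on CUTLL1 cells (Homo sapiens) for inhibition, read by resazurin assay, with a stated time of 48 h, in the presence of a further agent that is not named here (a higher number here means that more compound is needed for the effect, a lower number that less compound is needed), and two of the three entries are limits of the assay, not numbers:

compound 1 `Nc1ncc(-c2cccnc2)c(C2CC2)n1` - > 100000 nM (a limit)
compound 2 `Nc1ncc(-c2ccccn2)c(C2CC2)n1` - > 100000 nM (a limit)
compound 3 `Nc1ncc(-c2ccncc2Br)c(C2CC2)n1` - 75000 nM

Compound 3 is the only one of the three that returns an actual number. Compound 4 `C=Cc1cnccc1-c1cnc(N)nc1C1CC1` differs from compound 3 in a single place, with vinyl in place of bromo on an aromatic carbon. Among the compounds with values here, no measured pair of compounds differs in just one place, so the data offer no direct guide to the size of this step. Within the data shown here, with compound 3 at 75000 nM as the sole number to start from, a small downward step is expected, or none beyond the usual scatter. A limit instead of a number also remains possible for compound 4. The expected step of a 1.5-fold lower number from compound 3 to compound 4 (0.18 log units; within the scatter) is only an estimate. For compound 4 the expected value is 50000 nM (estimated range 15000 nM to 100000 nM).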

Compound 4, half-maximal effective concentration: 29000 nM
Compound 4: middle estimate off by 1.7-fold (0.24 log units), on the high side; the range from low to high includes it.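

Replacing bromo with vinyl gives a 2.6-fold lower number from compound 3 to compound 4 (0.41 log units; beyond the scatter) in this assay and so shows that the number responds to the group on this aromatic carbon, ortho to a large group and two atoms from the ring nitrogen. Neither group carries a hydrogen-bond donor, a hydrogen-bond acceptor or a net charge, so this step comes with no change in those counts. Compound 1 and compound 2 could not show such a step, since they return limits and not numbers: the limit of > 100000 nM in this assay, at which 2 of the 4 values shown sit.

On these data alone, whether the lower number comes from the arrival of vinyl or the loss of bromo stays open, as does what an amine, a methyl or a longer chain would give on this carbon. The compounds shown also give no reason for the step.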